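The compounds below may be only part of what the source reports. "The series", "measured", "known", "first", "only" and "open" are said of these compounds alone.

Measured so far in a functional assay on HeLa cells (Homo sapiens) for antiproliferative activity, with a stated time of 24 h; on this read-out lower numbers stand for stronger inhibition and higher numbers for weaker inhibition:
- compound 1, `NC(=O)c1c(NC(=O)c2ccccc2F)sc2c1CCN(Cc1ccc(Cl)cc1Cl)C2`: 27500 nM
- compound 2, `NC(=O)c1c(NC(=O)c2cccc([N+](=O)[O-])c2)sc2c1CCN(Cc1c(Cl)cccc1Cl)C2`: 46100 nM

Compound 2 gives the upper of the two numbers, yet the gap to compound 1 lies within the usual scatter of this assay, so the two cannot be separated on this read-out; neither may be called the weaker. Going by the values given here, no pair differing in a single place has been measured, so no step size is known from direct comparison. Among the compounds with values here, compound 1 and compound 2 differ in two places at once, the benzamide part and the dichlorobenzyl part, and their values say only that both changes together leave the number within the scatter.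

The next compound, compound 3, `NC(=O)c1c(NC(=O)c2cccc([N+](=O)[O-])c2)sc2c1CCN(Cc1ccc(Cl)cc1Cl)C2`, takes the step from compound 2 of 2,4-dichlorophenyl in place of 2,6-dichlorophenyl on a saturated chain carbon bound to an amine nitrogen in a ring. Its benzamide part is that of compound 2; its dichlorobenzyl part is that of compound 1. Nothing measured isolates this change, so no step beyond the scatter is expected in this assay in either direction. The step of a 1.4-fold lower number from compound 2 to compound 3 (0.15 log units; within the scatter) is the estimate, with wide uncertainty. Compound 3 is expected near 33000 nM, with a range of 12000 nM to 90000 nM.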

Compound 3, half-maximal inhibitory concentration: 33000 nM
Estimate against measurement, compound 3: no gap at the digits printed; the measured number falls inside the stated range.
By their numbers in this assay, from the lowest: compounds 1, 3 and 2 (each within the scatter of the next).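

In this assay, the exchange of 2,6-dichlorophenyl for 2,4-dichlorophenyl on a saturated chain carbon bound to an amine nitrogen in a ring now has a direct reading, with the rest of the structure unchanged: a 1.4-fold lower number from compound 2 to compound 3 (0.15 log units; within the scatter) marks this position as showing no step beyond the scatter for this change. The second single-place reading, 3-nitrophenyl in place of 2-fluorophenyl on a carbonyl carbon with the 2,4-dichlorophenyl group held constant, gives a 1.2-fold higher number from compound 1 to compound 3 (0.08 log units; within the scatter) and so also shows no step beyond the scatter. No independent information bears on these results.

Still open, from the compounds shown here alone, is whether the dichlorophenyl exchange reads the same way with 2-fluorophenyl on the carbonyl carbon, since the step is known only with 3-nitrophenyl there. Also open, going by these compounds, is whether a more different group moves the number beyond the scatter, such as an unsubstituted phenyl or a longer chain in place of the dichlorophenyl, or a carboxylic acid or an amine on the phenyl at the carbonyl carbon in place of the nitro group.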